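The source may hold more compounds than are shown below. What is called first, only, known or untested is meant among the compounds shown, and "the series" means these compounds.

The measured compounds:

Compound 1 `CCCC/C=C\c1cn([C@H]2C[C@H](O)[C@@H](CO)O2)c(=O)[nH]c1=O` — 361 ug/mL
Compound 2 `CCC#Cc1cn(C2O[C@H](CO)[C@@H](O)[C@@H]2O)c(=O)[nH]c1=O` — > 1000 ug/mL
Compound 3 `CC(C)(C)C#Cc1cn(C2O[C@H](CO)[C@@H](O)[C@H]2O)c(=O)[nH]c1=O` — 300 ug/mL

All three share one core and differ in the group on an aromatic carbon and in the sugar. In a functional assay on L1210 cells (Mus musculus) (on this read-out higher numbers stand for weaker inhibition and lower numbers for stronger inhibition), compound 1 gives 361 ug/mL, the higher of the two numbers reported. Compound 3 sits closest, and the gap between compound 1 and compound 3 lies within the usual scatter of this assay, so neither can be called the stronger inhibitor. The value of compound 2, > 1000 ug/mL, is a limit of this assay rather than a number; the only firm point about it is the limit of > 1000 ug/mL in this assay, at which 1 of the 3 values shown sits.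

Compound 4 `CCCCCC#Cc1cn([C@H]2C[C@H](O)[C@@H](CO)O2)c(=O)[nH]c1=O` has not yet been measured. It differs from compound 1 in one place: hept-1-yn-1-yl in place of hex-1-en-1-yl on an aromatic carbon. Within the data shown here, no pair of measured compounds shows this change on its own, since compound 2 and compound 3 carry a different sugar. The expected step of a 1.1-fold lower number from compound 1 to compound 4 (0.05 log units; within the scatter) is therefore none beyond the scatter. For compound 4 in this assay, the estimated value is 320 ug/mL, with a range from 110 ug/mL to 950 ug/mL.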

Compound 4, concentration for 50% inhibition: 219 ug/mL
Compound 4: middle estimate off by 1.5-fold (0.16 log units), on the high side; the measured number falls inside the stated range.
By their numbers in this assay, from the lowest: compounds 4, 3 and 1 (each within the scatter of the next). At a limit, above all of these: compound 2.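

In this assay, hept-1-yn-1-yl in place of hex-1-en-1-yl on this aromatic carbon gives a 1.6-fold lower number from compound 1 to compound 4 (0.22 log units; within the scatter) and so does not separate the two chains on the sugar of compound 1. This is the first pair shown that differs in this one place alone, as compound 2 and compound 3 carry a different sugar, and it shows that a chain with a double bond can give way to a chain with a triple bond and one more carbon without a change beyond the scatter. Nothing measured here bears on a reason for this step.

Bond type and chain length change together in this single step, so the share of each cannot be read, and the same swap on the sugar of compound 2 and compound 3 remains untested in the compounds shown. Also open, from the compounds shown here alone, is whether a much shorter chain, a longer chain, an amine or a carboxylic acid in place of hept-1-yn-1-yl would move the number beyond the scatter.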